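The source may report more compounds than this note shows. Statements on the series, on what has been measured and on what is new or still open speak of the compounds shown alone.

Compound 3, `Cc1cc(CCCC(=O)O)ccc1-c1noc(-c2ccc(C3CCCCC3)cc2)n1`, is the starting point here. In a functional assay on CHO cells with sphingosine 1-phosphate receptor 4 (Homo sapiens) as the target, read by GTPgammaS binding (on this read-out higher numbers stand for an effect only at larger amounts of compound and lower numbers for an effect already at smaller amounts), compound 3 gives only a limit, > 10000 nM, not a number. Its two neighbours in the series stand no differently. Compound 1, `Cc1ccccc1-c1noc(-c2ccc(C3CCCCC3)cc2)n1`, gives a limit of > 10000 nM in this assay. Compound 2, `Cc1cc(C(=O)O)ccc1-c1noc(-c2ccc(C3CCCCC3)cc2)n1`, likewise gives a limit of > 10000 nM in this assay. All three sit at the limit of > 10000 nM in this assay, at which 3 of the 3 values shown sit, so the step that the two limits leave unreadable from compound 1 to compound 2, the step that the two limits leave unreadable from compound 1 to compound 3 and the step that the two limits leave unreadable from compound 2 to compound 3 cannot be read in size or direction.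

Compound 4, `Cc1cc(CCCCCC(=O)O)ccc1-c1noc(-c2ccc(C3CCCCC3)cc2)n1`, arises from compound 3 by 2-carboxyethyl in place of carboxy on a saturated chain carbon, three bonds along the chain from an aromatic carbon, a 2-carboxyethyl in place of carboxy on a saturated chain carbon, three bonds along the chain from an aromatic carbon. Among the compounds with values here, no measured step bears on such a lengthening with a readable size; every value so far is a limit. The step that the limit leaves unreadable from compound 3 to compound 4 is therefore expected to stay within the scatter. Compound 4 is estimated at 15000 nM in this assay, with a range from 5000 nM to 50000 nM, and most likely again only a limit.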

Compound 4, half-maximal effective concentration: > 10000 nM
Compound 4 was reported as a limit (the forecaster's own chance of this, stated with the estimate: 80%); the middle value does not contradict the limit.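

Within the data shown here, compound 4 again gives only a limit, as do compound 1, compound 2 and compound 3, so no step involving compound 4 can be read in size or direction: the limit of > 10000 nM in this assay, at which 4 of the 4 values shown sit.

The compounds shown leave open whether any relative of this series gives a measurable effect in this assay at all.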